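Swapping a Ring Methyl for Chloro on the Acid Side

The compounds below may be only part of what the source reports. "The series", "measured", "known", "first", "only" and "open" are said of these compounds alone.

Three compounds sharing one core have been run in an assay on HEK293 cells for positive allosteric modulation of metabotropic glutamate receptor 2 (Rattus norvegicus), read by thallium flux, with a stated time of 2.5 min; on this read-out higher numbers stand for larger maximal responses and lower numbers for smaller maximal responses. Compound 1 `Cc1cc(C(=O)O)ccc1OCCCCOc1ccc(C(=O)CC(C)C)c(O)c1C` gives 83.9%, compound 2 `CCCC(=O)c1ccc(OCCCCOc2cc(C(=O)O)ccc2OC)c(C)c1O` gives 82.8%, and compound 3 `CCCC(=O)c1ccc(OCCCCOc2ccc(C(=O)O)cc2C)c(C)c1O` gives 79.3%. Compound 1 stands at the top of these three numbers, yet the other two sit within the scatter of it, so the three cannot really be told apart. Among the measured compounds shown here, the only single-point step known, a number 4.6 percentage points lower from compound 1 to compound 3 (within the scatter), concerns a chain methyl and not a ring position. Compound 4 `Cc1c(OCCCCOc2ccc(C(=O)O)cc2Cl)ccc(C(=O)CC(C)C)c1O` differs from compound 1 by chloro in place of methyl on an aromatic carbon. For the measured compounds named here, no measured step touches this exchange, and every value so far lies in one narrow band, so no change beyond the scatter is expected. Compound 4 is estimated at 82%, between 66% and 96%, which would be a step of a number 1.9 percentage points lower from compound 1 to compound 4 (within the scatter).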

Compound 4, largest response reached (reported as percent of maximum), in percent of the reference or control that the assay uses: 99.5%
Compound 4: middle estimate off by 17.5 percentage points, on the low side, outside the stated range (above it).
By their numbers in this assay, from the lowest: compounds 3, 2 and 1 (each within the scatter of the next); then compound 4.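

This ring position, ortho to a large group and meta to a carboxy group, is not silent in this assay: chloro in place of methyl gives a number 15.6 percentage points higher from compound 1 to compound 4 (beyond the scatter). Among the compounds shown here, that is the first step in this set to clear the scatter, so the maximal response can move with a single-atom exchange on the ring carrying the carboxy group. Nothing available here explains the gain. On these data alone, whether bromo or fluoro at this carbon would go the same way stays open. So does whether chloro would give a similar step with the ketone chain of compound 3.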